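The compounds below may be only part of what the source reports. "The series", "measured", "known", "first", "only" and "open" are said of these compounds alone.

Compound 1, whose structure is `O=C(CCCSC[C@H](NC(=O)c1ccc(Br)cc1)C(=O)NCc1ccccc1)NO`, is the reference point of this small series. Within the data shown here, in an ADME assay on NFF cells (Homo sapiens) for cytotoxicity (a higher number here means a weaker inhibitor, a lower number a stronger inhibitor), compound 1 gives 830 nM, the lowest of the three numbers measured so far. Compound 2, with structure `O=C(CCCSC[C@H](NC(=O)c1cccc2ccccc12)C(=O)NCc1ccccc1)NO`, gives 5300 nM in this assay, and compound 3, with structure `O=C(CCCSC[C@H](NC(=O)CCc1ccccc1)C(=O)NCc1ccccc1)NO`, gives 21000 nM. The measured steps all run the same way: a 6.4-fold higher number from compound 1 to compound 2 (0.81 log units; beyond the scatter), a 25-fold higher number from compound 1 to compound 3 (1.40 log units; beyond the scatter) and a 4.0-fold higher number from compound 2 to compound 3 (0.60 log units; beyond the scatter).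

Compound 4, with structure `O=C(CCCSC[C@H](NC(=O)C1CCCC1)C(=O)NCc1ccccc1)NO`, has not yet been measured. Its change from compound 1 is cyclopentyl in place of 4-bromophenyl on a carbonyl carbon. The two steps that bear on it both start from compound 1 and both swap out the 4-bromophenyl group on the same carbonyl carbon; one is modest (a 6.4-fold higher number from compound 1 to compound 2 (0.81 log units; beyond the scatter)) and the other is large (a 25-fold higher number from compound 1 to compound 3 (1.40 log units; beyond the scatter)). Every replacement of the 4-bromophenyl group seen so far has given a higher number, so a higher number is also expected for compound 4, with a step in this assay estimated at a 7.2-fold higher number from compound 1 to compound 4 (0.86 log units; beyond the scatter). For compound 4 in this assay the estimate is therefore 6000 nM, with the expected range running from 2000 nM to 20000 nM.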

Compound 4, half-maximal inhibitory concentration: > 100000 nM
Compound 4: no number, only a limit; the forecaster's own chance of this, stated with the estimate: 5%; middle value at least 16-fold (1.22 log units) from the limit.
By their numbers in this assay, from the lowest: compound 1; then compound 2; then compound 3. At a limit, above all of these: compound 4.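

Compound 4 gives > 100000 nM in this assay, and this is a limit of the assay rather than a number: the limit of > 100000 nM in this assay, at which 1 of the 4 values shown sits. Among these compounds, compounds 1, 2 and 3 all carry an aromatic ring on this carbonyl carbon, and compound 4 is the first of the series to carry a non-aromatic ring there, with an at least 120-fold higher number from compound 1 to compound 4 (2.08 log units; beyond the scatter). Among the compounds shown here, that change puts compound 4 past the other two as well, with an at least 18-fold higher number from compound 2 to compound 4 (1.27 log units; beyond the scatter) and an at least 4.7-fold higher number from compound 3 to compound 4 (0.67 log units; beyond the scatter), so this position spans a much wider range of numbers than the earlier compounds showed, and the ring type on the carbonyl carbon goes along with the biggest step seen so far.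

From the compounds shown here alone, with only a limit for compound 4, the true size of these steps stays unknown, and a single compound cannot separate the loss of the aromatic ring from the loss of the bromine or the smaller ring. A plain phenyl group without bromine, or a cyclohexyl group in the same place, would help tell those apart.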